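The source may report more compounds than this note shows. Statements on the series, on what has been measured and on what is new or still open speak of the compounds shown alone.

Compound 1 `C=C1CC[C@@H]2[C@](C)(COC(C)=O)[C@H](OC(C)=O)CC[C@@]2(C)[C@@H]1C/C=C1/C(=O)OC[C@H]1OC(C)=O` carries the core that compounds 2, 3 and 4 share. In a functional assay on MCF7 cells (Homo sapiens) for cytotoxicity, read by sulforhodamine B assay (on this read-out lower numbers stand for an effect already at smaller amounts and higher numbers for an effect only at larger amounts of compound), compound 1 gives 10 uM. Compound 2 `C=C1CC[C@@H]2[C@](C)(CO)[C@H](OC(C)=O)CC[C@@]2(C)[C@@H]1C/C=C1/C(=O)OC[C@H]1OC(C)=O` differs from compound 1 by hydrogen in place of acetyl on an oxygen on a saturated carbon; in this assay compound 2 gives 11 uM, so the change made a 1.1-fold higher number from compound 1 to compound 2 (0.04 log units; within the scatter). Compound 3 `C=C1CC[C@@H]2[C@](C)(CO[Si](C)(C)C(C)(C)C)[C@H](OC(C)=O)CC[C@@]2(C)[C@@H]1C/C=C1/C(=O)OC[C@H]1OC(C)=O` differs from compound 1 by a group of 7 heavy atoms (6 carbon, 1 silicon; no ring) in place of a group of 3 heavy atoms (2 carbon, 1 oxygen; no ring), on an oxygen on a saturated carbon, and in this assay compound 3 gives 2.84 uM. Compound 4 `C=C1CC[C@@H]2[C@](C)(CO[Si](C)(C)C(C)(C)C)[C@H](O)CC[C@@]2(C)[C@@H]1C/C=C1/C(=O)OC[C@H]1OC(C)=O` has not yet been measured; it differs from compound 3 by hydrogen in place of acetyl on an oxygen on a saturated carbon. This is the same kind of change as that from compound 1 to compound 2, but the place differs: there the other neighbour of the saturated carbon is a saturated chain carbon, here it is a saturated ring carbon. Because the earlier step was a 1.1-fold higher number from compound 1 to compound 2 (0.04 log units; within the scatter), a step of about the same size is expected here, a 1.1-fold higher number from compound 3 to compound 4 (0.02 log units; within the scatter). Compound 4 is therefore estimated at 3 uM in this assay, between 1.5 uM and 6.5 uM.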

Compound 4, concentration for half-maximal effect: 10.4 uM
Beside the measured number, compound 4's estimate is 3.5-fold (0.54 log units) below it; the whole stated range lies below it.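

In this assay, hydrogen in place of acetyl gave a 3.7-fold higher number from compound 3 to compound 4 (0.56 log units; beyond the scatter), so the same change did not keep its size from one core to the other: the same change on two cores in this assay, a 1.1-fold higher number (0.04 log units; within the scatter) from compound 1 to compound 2 and a 3.7-fold higher number (0.56 log units; beyond the scatter) from compound 3 to compound 4, 3.3-fold (0.52 log units) apart, beyond the scatter of two such steps

The two steps also differ in place, the earlier one on a saturated carbon with a saturated chain carbon as its other neighbour and the new one on a saturated carbon with a saturated ring carbon, so the core and the place cannot be told apart. With a single pair on each side, this shows that the earlier step did not transfer here, but it gives no rule for other cores and does not show why the steps differ.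

The compounds shown leave open how a methyl ether or a longer ester such as a butyrate on this oxygen would compare with compound 3 and compound 4. Also open, as far as these compounds go, is whether an amine in place of the hydroxy would behave as compound 4 does.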